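The source may hold more compounds than are shown below. What is called first, only, known or untested is meant among the compounds shown, and "the series" means these compounds.

Within the data shown here, compound 1 `COc1ccc(CNc2nc([SeH])nc3ccccc23)cc1` gives 7110 nM in a functional assay on HTB-54 cells (Homo sapiens) for cytotoxicity, read by MTT assay, with a stated time of 72 h (a lower number here means a stronger inhibitor of growth, a higher number a weaker inhibitor of growth), the lower of the two numbers so far; compound 2 `[SeH]c1nc(NCc2ccccc2)c2ccccc2n1` gives 31200 nM, and the step of a 4.4-fold higher number from compound 1 to compound 2 (0.64 log units; beyond the scatter) follows hydrogen in place of methoxy on an aromatic carbon. Compound 3 `COc1ccc(CNc2nc(SC)nc3ccccc23)cc1` keeps that methoxy and differs from compound 1 by a group of 2 heavy atoms (1 carbon, 1 sulfur; no ring) in place of one selenium atom, on an aromatic carbon. Among the measured compounds shown here, no measured step touches this position, so the one step available, concerning the methoxy, does not bear on it directly. A modest step in this assay is therefore expected, a 1.7-fold higher number from compound 1 to compound 3 (0.23 log units; within the scatter). Compound 3 is estimated at 12000 nM, within 3000 nM to 50000 nM.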

Compound 3, concentration for 50% growth inhibition: 93700 nM
Beside the measured number, compound 3's estimate is 7.8-fold (0.89 log units) below it, outside the stated range (above it).
By their numbers in this assay, from the lowest: compound 1; then compound 2; then compound 3.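

This position is not silent in this assay: with the methoxy kept, methylsulfanyl in place of selenium, on the aromatic carbon between two ring nitrogen atoms, gives a 13-fold higher number from compound 1 to compound 3 (1.12 log units; beyond the scatter). Among these compounds, that step is large, whereas the only earlier step, at the methoxy, is modest. Nothing available explains the change at this position.

The compounds shown leave open whether the step follows the loss of selenium or the added methyl carbon; a methylselanyl group or a thiol here would separate the two. Also open, on these data alone, is whether the step holds without the methoxy.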